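The source may hold more compounds than are shown below. What is called first, only, known or untested is meant among the compounds shown, and "the series" means these compounds.

Going by the values given here, compound 2 `c1ccc(-c2cn3ccnc3c(-c3ccc4ncn(C5CCCCC5)c4c3)n2)cc1` holds the highest of the two numbers measured so far in a functional assay on OVCAR-3 cells (Homo sapiens) for inhibition, read by sulforhodamine B assay, with a stated time of 48 h, tested at 10 uM; on this read-out lower numbers stand for less inhibition and higher numbers for more inhibition at the one concentration tested (going by the name of the read-out): compound 2 gives 41.8%, while compound 1 `Brc1cn2ccnc2c(-c2ccc3ncn(C4CCCCC4)c3c2)n1` gives 15.8%. Among the compounds with values here, the one measured step, a number 26 percentage points higher from compound 1 to compound 2 (beyond the scatter), comes from phenyl in place of bromo and does not speak to what a substituent on that phenyl would do. Compound 3 `COc1ccc(-c2cn3ccnc3c(-c3ccc4ncn(C5CCCCC5)c4c3)n2)cc1` differs from compound 2 by methoxy in place of hydrogen on an aromatic carbon, read one bond further out as phenyl to 4-methoxyphenyl. Within the data shown here, with no measured step bearing on this change, compound 3 is expected to stay near compound 2, a step of a number 3.2 percentage points higher from compound 2 to compound 3 (within the scatter) in this assay, within the scatter. The estimate for compound 3 is 45%, ranging from 25% to 65%.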

Compound 3, a percentage reported as inhibition, at one concentration (the size of the read-out at that concentration, not a potency): -26.5%
Compound 3: middle estimate off by 71.5 percentage points, on the high side; measured number outside the range, below it.
By their numbers in this assay, from the lowest: compound 3; then compound 1; then compound 2.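

In this assay the number does not stay level with every small addition to the outer phenyl ring: methoxy in place of hydrogen, para to a large group, gives a number 68.3 percentage points lower from compound 2 to compound 3 (beyond the scatter) in a single change. The gain seen for phenyl over bromo does not carry over to 4-methoxyphenyl, which gives a number 42.3 percentage points lower from compound 1 to compound 3 (beyond the scatter) and leaves compound 3 at -26.5% as the lowest of the three. Nothing available here accounts for this drop. As far as these compounds go, whether it belongs to methoxy itself or to any substituent at this place remains open, and a fluoro, hydroxy or amino group there would separate these readings.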